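The compounds below may be only part of what the source reports. "The series", "measured", "known", "first", "only" and "open" are said of these compounds alone.

Working notes on the series. In a physicochemical assay for solubility, in phosphate buffer, at pH 7.4 (on this read-out higher numbers stand for higher solubility and lower numbers for lower solubility), compound 1 `NC(=O)C1CCN(c2nccnc2OC2CN(c3ccc4ccccc4n3)C2)CC1` gives 14000 nM and compound 2 `OCc1cccc(-c2nccnc2OC2CN(c3ccc4ccccc4n3)C2)c1` gives 29000 nM, the higher of the two numbers. Compound 3 `c1ccc2nc(N3CC(Oc4nccnc4-c4cncnc4)C3)ccc2c1` is not yet measured. It carries pyrimidin-5-yl in place of 3-(hydroxymethyl)phenyl on an aromatic carbon, ortho to a large group (pyrimidin-5-yl in place of 3-(hydroxymethyl)phenyl on an aromatic carbon). Among the compounds with values here, only one measured step bears on this change, and it does so loosely: a 2.1-fold higher number from compound 1 to compound 2 (0.32 log units; beyond the scatter), a modest step that brought in 3-(hydroxymethyl)phenyl in place of 4-carbamoylpiperidin-1-yl at the same place. Within the data shown here, no measured compound carries pyrimidin-5-yl, so in this assay a small step downward is expected, with no clear move beyond the scatter. The estimated step is a 1.5-fold lower number from compound 2 to compound 3 (0.16 log units; within the scatter). The estimated value for compound 3 is 20000 nM, with an expected range of 7000 nM to 55000 nM.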

Compound 3, solubility: 254000 nM
The estimate for compound 3 lay 13-fold (1.10 log units) below the measured number; measured number above the stated range.
By their numbers in this assay, from the lowest: compound 1; then compound 2; then compound 3.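

In this assay the place ortho to a large group spans a far wider range than the earlier pair showed: pyrimidin-5-yl gives an 8.8-fold higher number from compound 2 to compound 3 (0.94 log units; beyond the scatter) when it replaces 3-(hydroxymethyl)phenyl, and an 18-fold higher number from compound 1 to compound 3 (1.26 log units; beyond the scatter) when it replaces 4-carbamoylpiperidin-1-yl. Compound 3 carries no hydrogen-bond donor on this substituent and still has the highest number of the three, so a donor here is not required for a high number in this set. Nothing available accounts for the size of the rise.

On these data alone, it remains open whether the rise follows the two ring nitrogens or the loss of the hydroxymethyl group, which pyridin-3-yl or plain phenyl at this place would help separate. Also open, as far as these compounds go, is how an amine or a carboxylic acid on the pyrimidin-5-yl ring would compare.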